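Working notes: phenyl to 4-fluorophenyl on compound 3

The compounds below may be only part of what the source reports. "The series", "measured", "known", "first", "only" and "open" are said of these compounds alone.

- compound 1 `Cc1ccc(S(=O)(=O)NC(=O)/C=C/c2ccc3c(c2)OCCO3)cc1` gives > 100 ug/mL (a limit)
- compound 2 `O=C(/C=C/c1ccc2c(c1)OCCO2)NS(=O)(=O)c1ccc(F)cc1` gives 52.1 ug/mL
- compound 3 `O=C(/C=C/c1ccc2c(c1)OCCCO2)NS(=O)(=O)c1ccccc1` gives 53.9 ug/mL

In a functional assay on MCF7 cells (Homo sapiens) for antiproliferative activity, read by MTT assay, with a stated time of 48 h (a higher number here means a weaker inhibitor, a lower number a stronger inhibitor), compound 3 gives 53.9 ug/mL and compound 2 gives 52.1 ug/mL with the two values within the scatter of each other. Compound 1 gives > 100 ug/mL as a limit of the assay and not a number.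

Compound 4 `O=C(/C=C/c1ccc2c(c1)OCCCO2)NS(=O)(=O)c1ccc(F)cc1` is compound 3 with fluoro in place of hydrogen on an aromatic carbon, para to a large group (fluoro in place of hydrogen on an aromatic carbon).

For the measured compounds named here, one measured step bears on this change. It is an at least 1.9-fold lower number from compound 1 to compound 2 (0.28 log units; that floor lies within the scatter) and there fluoro replaces methyl, not hydrogen, on the core of compound 1. That step starts from a limit (the limit of > 100 ug/mL in this assay, at which 1 of the 3 values shown sits) and so gives only a floor, with no firm size for a fluoro step. At most a weak lean towards a lower number is expected, and nothing beyond the scatter. The expected step is a 1.2-fold lower number from compound 3 to compound 4 (0.08 log units; within the scatter) and it is an estimate. Expected for compound 4 is 45 ug/mL with an estimated range from 20 ug/mL to 100 ug/mL and the measurement is still to come.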

Compound 4, half-maximal inhibitory concentration: > 100 ug/mL
Compound 4 gave a limit, no number (the forecaster's own chance of this, stated with the estimate: 15%); middle value at least 2.2-fold (0.34 log units) from the limit.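

In this assay compound 4 gives > 100 ug/mL, which is a limit of the assay and not a number. Fluoro in place of hydrogen, para to a large group, reads as an at least 1.8-fold higher number from compound 3 to compound 4 (0.26 log units; that floor lies within the scatter), so on this core the change gives no sign of the lower number that the step between compound 1 and compound 2 had left as a weak lean. On these data alone, the direction of the step is all that can be taken from it, and its true size stays unknown because one end rests on a limit: the limit of > 100 ug/mL in this assay, at which 2 of the 4 values shown sit.

Open, as far as these compounds go, is whether another group at this place, such as an amine, a carboxylic acid or a methoxy group, gives a value inside the range of the assay. Also open, from the compounds shown here alone, is how a plain phenyl group reads on the core of compound 1, which would give a fluoro in place of hydrogen step there to set beside this one.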